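A few compounds are considered here, and "the series" means these few. Any claim that something is new, unique, unknown or untested is made for them only; others in the source may bear on it.

In a functional assay on SW480 cells (Homo sapiens) for antiproliferative activity, read by MTT assay, with a stated time of 48 h (on this read-out lower numbers stand for stronger inhibition and higher numbers for weaker inhibition), compound 2 (`CCCCCCCC(CCO)n1cnc2c(OC)ncnc21`) gives 23900 nM and compound 3 (`CCCCCCCC(CCO)n1cnc2c(NC)ncnc21`) gives 15300 nM. For the measured compounds named here, these are the only two exact numbers so far, and they cannot be told apart: the change of methoxy to methylamino on an aromatic carbon gives a 1.6-fold lower number from compound 2 to compound 3 (0.19 log units; within the scatter). Compound 1 (`CCCCCC(CCO)n1cnc2c(N(C)C)ncnc21`) gives > 50000 nM, which is a limit of the assay and not a number.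

Compound 4 (`CCCCCCCC(CCO)n1cnc2c(N(C)C)ncnc21`) is compound 3 with one alteration, methyl in place of hydrogen on a nitrogen on an aromatic ring, so methylamino becomes dimethylamino. Going by the values given here, no measured step tests this exact change. The closest one, a 1.6-fold lower number from compound 2 to compound 3 (0.19 log units; within the scatter), is small. Compound 1 carries the same dimethylamino group on a different chain and sits at the limit of > 50000 nM in this assay, at which 1 of the 3 values shown sits, so it is only a loose hint towards weaker inhibition.

A small rise is therefore expected, with an estimated 1.3-fold higher number from compound 3 to compound 4 (0.12 log units; within the scatter). The estimated value for compound 4 is 20000 nM, within an expected range of 8000 nM to 45000 nM.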

Compound 4, half-maximal inhibitory concentration: > 50000 nM
Compound 4: no number, only a limit; the forecaster's own chance of this, stated with the estimate: 15%; middle value at least 2.5-fold (0.39 log units) from the limit.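

Placing methyl on a nitrogen on an aromatic ring is the first change in this series to lie beyond the scatter, giving an at least 3.2-fold higher number from compound 3 to compound 4 (0.51 log units; beyond the scatter). Methoxy and methylamino could not be told apart, but dimethylamino in the same place gives an at least 2.0-fold higher number from compound 2 to compound 4 (0.32 log units; beyond the scatter), so this position does respond to the group it carries, and one added methyl is enough to weaken inhibition. The step between compound 1 and compound 4 cannot be read, since both values are limits and not numbers: the limit of > 50000 nM in this assay, at which 2 of the 4 values shown sit.

From the compounds shown here alone, the true size of the rise stays open, as compound 4 has only a limit. Also open, going by these compounds, is how a plain amino group or an ethylamino group in this place would compare with the methylamino group of compound 3.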